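Ester Group Swap on the Shared Core: Isopropyl to 2-Phenylpropyl

A few compounds are considered here, and "the series" means these few. Any claim that something is new, unique, unknown or untested is made for them only; others in the source may bear on it.

Measured compounds:
compound 1 `COc1cc(O)c(C(=O)OCC2CCCCC2)c(/C=C/CN2C(=O)C=CC2=O)c1` gives 71%
compound 2 `COc1cc(O)c(C(=O)OC(C)C)c(/C=C/CN2C(=O)C=CC2=O)c1` gives 65.7%
compound 3 `CCN(CC)C/C=C/C(=O)NC/C=C/c1cc(OCCc2ccc(F)cc2)cc(O)c1C(=O)OC(C)C` gives 36.8%

In a functional assay on HL-60 cells (Homo sapiens) for inhibition, read by luminescence, with a stated time of 72 h, tested at 5 uM (a higher number here means more inhibition of growth at the concentration tested, a lower number less inhibition of growth), compound 2 stands second of the three numbers. Compound 1 sits nearest, a step of a number 5.3 percentage points lower from compound 1 to compound 2 (within the scatter) that stays within the scatter. Going by the values given here, compound 3 lies furthest away with 36.8%, but it differs from compound 2 in several places at once, so no single step links them.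

The new compound 4 `COc1cc(O)c(C(=O)OCC(C)c2ccccc2)c(/C=C/CN2C(=O)C=CC2=O)c1` differs from compound 2 in one place: 2-phenylpropyl in place of isopropyl on an oxygen next to a carbonyl group. Among the compounds with values here, the only measured step that touches the same oxygen is the one from compound 1 to compound 2, where a larger ring-bearing group was replaced by isopropyl with no change beyond the scatter. Compound 4 reverses that direction, putting a larger group carrying a ring back in. On that evidence a step of about a number 3.3 percentage points higher from compound 2 to compound 4 (within the scatter) is expected, which is no change beyond the scatter. Compound 4 is therefore estimated at 69%, within a range from 52% to 82%.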

Compound 4, percent growth inhibition at one concentration: 56%
Compound 4: the middle estimate sits 13 percentage points above what was measured, within the range that was stated.
By their numbers in this assay, from the lowest: compound 3; then compounds 4, 2 and 1 (each within the scatter of the next, the first and the last beyond it).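

In this assay, the ester oxygen accepts 2-phenylpropyl, with its six-membered aromatic ring, in place of isopropyl: a number 9.7 percentage points lower from compound 2 to compound 4 (within the scatter) stays within the scatter, so this swap cannot be told apart from no change. Going by these compounds alone, the comparison with the cyclohexylmethyl ester adds something the earlier compounds could not show: a number 15 percentage points lower from compound 1 to compound 4 (beyond the scatter) is a modest step but lies beyond the scatter, so these two ring-bearing groups are not interchangeable here, even though each lies within the scatter of isopropyl. Nothing available explains this difference between the two ring-bearing groups.

All the ester groups shown are built from carbon and hydrogen alone, so it remains open how an ester group carrying an amine or a carboxylic acid would behave. A single test concentration also leaves open how these compounds would compare across a range of concentrations.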